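Cutting an amide back to an acid on a shared core

This account rests on a few compounds, and the source may have more. Where it says the series, first, only, none or still open, it means among the compounds named here.

Of the compounds shown here, three have been tested in a toxicity assay on A549 cells (Homo sapiens) for cytotoxicity, read by luminescence and CellTiter-Glo, with a stated time of 48 h; on this read-out lower numbers stand for higher toxicity in this test and higher numbers for lower toxicity in this test. Compound 1 `CC(C)(C)CC(C)(C)Nc1c(-c2ccc(Br)cc2)nc2ncccn12` gives 32000 nM. Compound 2 `CC(C)(C)CC(C)(C)Nc1nc2ncccn2c1-c1ccc(Br)cc1` reaches only a limit of the test, > 100000 nM. Compound 3 `CCNC(=O)CCCOc1ccc(-c2nc3ncccn3c2NC2CCCCC2)cc1` likewise reaches only a limit, > 100000 nM. So compound 3 stands at the limit of > 100000 nM in this assay, at which 2 of the 3 values shown sit, and no number separates it from compound 2; only compound 1 gives a value inside the measured range. Compound 4 `O=C(O)CCCOc1ccc(-c2nc3ncccn3c2NC2CCCCC2)cc1` has not yet been measured. It differs from compound 3 in one place: hydroxy in place of ethylamino on a carbonyl carbon. Among the compounds with values here, no measured pair of compounds carries this change, so nothing measured shows its size. In this assay the change from compound 3 to compound 4 is expected to bring no shift beyond the usual scatter, and compound 4 is expected to sit again at the limit rather than give a number. For compound 4 the estimate is 100000 nM, with a range from 50000 nM to 200000 nM, which means an expected step of a number no higher from compound 3 to compound 4 (the limit leaves the size open).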

Compound 4, half-maximal cytotoxic concentration: > 100000 nM
Compound 4 ended at the assay's limit; the forecaster's own chance of this, stated with the estimate: 80%; the middle value lies on the limit itself.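

Within the data shown here, compound 3 and compound 4 both stop at a limit of this assay rather than at a number, so no step between them can be read: the limit of > 100000 nM in this assay, at which 3 of the 4 values shown sit. The compounds shown leave open whether hydroxy in place of ethylamino on a carbonyl carbon changes this read-out at all, and by how much.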